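Swapping an anilino aryl for a dichlorobenzyl group

The source may report more compounds than this note shows. Statements on the series, on what has been measured and on what is new or still open speak of the compounds shown alone.

The three measured compounds share one core and differ only in the group on the amine nitrogen of the side chain. Compound 1 `CCN(CC(=O)N1CCC[C@H](c2ccccc2)[C@@H]1CN1CCCC1)c1ccc(Cl)c(Cl)c1` gives 31.6 nM in an assay on HEK293 cells for displacement of a labelled ligand from Urotensin-2 receptor (Homo sapiens); a higher number here means a weaker inhibitor, a lower number a stronger inhibitor. Compound 2 `Cc1ccc(N(C)CC(=O)N2CCC[C@H](c3ccccc3)[C@@H]2CN2CCCC2)cc1C` gives 200 nM in this assay, and compound 3 `CN(CC(=O)N1CCC[C@H](c2ccccc2)[C@@H]1CN1CCCC1)c1cccc(C(F)(F)F)c1` gives 100 nM. For the measured compounds named here, compound 3 therefore stands second highest of the three numbers: the step of a 2.0-fold lower number from compound 2 to compound 3 (0.30 log units; within the scatter) is within the scatter, while compound 1 sits at a lower number beyond the scatter, though no single step links compound 1 and compound 3.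

Compound 4 `CN(CC(=O)N1CCC[C@H](c2ccccc2)[C@@H]1CN1CCCC1)Cc1ccc(Cl)c(Cl)c1` has not been measured. It differs from compound 3 by 3,4-dichlorobenzyl in place of 3-(trifluoromethyl)phenyl on an amine nitrogen. Going by the values given here, no measured step bears directly on this change: the only step seen, from compound 2 to compound 3, exchanges one aryl group for another on the same nitrogen and is within the scatter, and nothing shows what placing a saturated carbon between the nitrogen and the ring does. The dichloro pattern of compound 4 also occurs in compound 1, which gives 31.6 nM, but compound 1 carries a different alkyl group on the nitrogen, so that value is only a loose hint.

Compound 4 is therefore expected to show a step of no change at the digits printed from compound 3 to compound 4 (within the scatter), that is, no change beyond the scatter, with the estimate for compound 4 at 100 nM and a range of 20 nM to 500 nM.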

Compound 4, inhibition constant: 3980 nM
Estimate against measurement, compound 4: 40-fold (1.60 log units) below, and the stated range ends below it.
By their numbers in this assay, from the lowest: compound 1; then compounds 3 and 2 (each within the scatter of the next); then compound 4.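

In this assay, for the compounds shown here, the amine nitrogen of the side chain proved far less forgiving than the earlier compounds suggested: the exchange of one aryl group for another had stayed within the scatter at a 2.0-fold lower number from compound 2 to compound 3 (0.30 log units; within the scatter) but the entry of 3,4-dichlorobenzyl gave a 40-fold higher number from compound 3 to compound 4 (1.60 log units; beyond the scatter) and likewise a 20-fold higher number from compound 2 to compound 4 (1.30 log units; beyond the scatter) in a large loss. Among the compounds that differ in this one place, therefore, the two groups with the ring attached directly to this nitrogen read close together, and the single benzyl group stands well apart from both of them. No measurement shown here accounts for this loss, and the reason for it remains unknown.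

The step changes the link to the ring and the groups on the ring at once, so the compounds shown cannot say which of the two carries the loss. A 3-(trifluoromethyl)benzyl group on the same nitrogen would separate them, and a longer chain such as 2-phenylethyl would show whether the loss continues as the chain grows.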